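A Furanyl Variant on the Shared Core

The compounds below may be only part of what the source reports. "The series", "measured", "known", "first", "only" and "open" are said of these compounds alone.

Compound 3 `COc1ccc(C2C(C#N)=C(N)N(c3ccc(S(N)(=O)=O)cc3)C3=C2C(=O)CCC3)c2ccccc12` gives 10% in a functional assay on Ehrlich cells (Mus musculus) for antiproliferative activity, read by trypan blue exclusion, with a stated time of 2 h, tested at 25 ug/mL; on this read-out higher numbers stand for a stronger effect at the one concentration tested and lower numbers for a weaker effect. It stands level with compound 2 `N#CC1=C(N)N(c2ccc(S(N)(=O)=O)cc2)C2=C(C(=O)CCC2)C1/C=C/c1ccccc1`, which gives 10%, the two together the lowest of the three numbers, while compound 1 `Cc1ccc(C2C(C#N)=C(N)N(c3ccc(S(N)(=O)=O)cc3)C3=C2C(=O)CCC3)cc1` gives 30%. Compound 4 `Cc1ccoc1C1C(C#N)=C(N)N(c2ccc(S(N)(=O)=O)cc2)C2=C1C(=O)CCC2` differs from compound 3 in one place: 3-methylfuran-2-yl in place of 4-methoxynaphthalen-1-yl on a saturated ring carbon. Among the measured compounds shown here, the steps that bear on this are a number 20 percentage points lower from compound 1 to compound 3 (beyond the scatter), a number 20 percentage points lower from compound 1 to compound 2 (beyond the scatter) and no change at the digits printed from compound 2 to compound 3 (within the scatter), all exchanges of the group on the same saturated ring carbon. For the measured compounds named here, no measured step involves a 3-methylfuran-2-yl group, so the direction is open. A value between those of compound 3 and compound 1 is estimated, so compound 4 is expected to give 17%, between 5% and 35%, a step of a number 7 percentage points higher from compound 3 to compound 4 (within the scatter).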

Compound 4, a percentage reported as activity, at one concentration (the size of the read-out at that concentration, not a potency): 10%
The estimate for compound 4 lay 7 percentage points above the measured number; the measured number falls inside the stated range.
By their numbers in this assay, from the lowest: compounds 2, 3 and 4 (each within the scatter of the next); then compound 1.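

In this assay, the 3-methylfuran-2-yl group gives no change at the digits printed from compound 3 to compound 4 (within the scatter) and no change at the digits printed from compound 2 to compound 4 (within the scatter), so on this saturated ring carbon a single five-membered aromatic ring reads level with both the 4-methoxynaphthalen-1-yl and 2-phenylethenyl groups. It also gives a number 20 percentage points lower from compound 1 to compound 4 (beyond the scatter), so among these four compounds only the 4-methylphenyl group stands apart from the rest. Nothing available here accounts for these readings.

As far as these compounds go, it remains open whether a phenyl ring carrying an amine or a carboxylic acid at this carbon would read level with compound 1, or differently.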